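A few compounds are considered here, and "the series" means these few. Any claim that something is new, unique, unknown or untested is made for them only; others in the source may bear on it.

In a functional assay on UACC-62 cells (Homo sapiens) for inhibition, read by sulforhodamine B assay, with a stated time of 48 h, tested at 10 uM (on this read-out lower numbers stand for less inhibition and higher numbers for more inhibition at the one concentration tested (going by the name of the read-out)), compound 1 `O=Cc1ccc(-c2cn3ccnc3c(-c3ccc4ncn(C5CCCCC5)c4c3)n2)cc1` gives 37.1%, compound 2 `FC(F)(F)c1cccc(-c2cn3ccnc3c(-c3ccc4ncn(C5CCCCC5)c4c3)n2)c1` gives 4.33%, and compound 3 `CCc1ccc(-c2cn3ccnc3c(-c3ccc4ncn(Cc5ccccc5)c4c3)n2)cc1` gives 24.9%. Among these three numbers compound 3 stands second highest, below compound 1 and above compound 2. For the measured compounds named here, the only step measured between two compounds that differ in one place is a number 32.8 percentage points lower from compound 1 to compound 2 (beyond the scatter), which swaps one aryl group for another on an aromatic carbon; it is the single step that bears on the change considered here. Compound 4 `c1ccc(Cn2cnc3ccc(-c4nc(-c5cccc6ccccc56)cn5ccnc45)cc32)cc1` differs from compound 3 by naphthalen-1-yl in place of 4-ethylphenyl on an aromatic carbon. On that one large downward step alone, a smaller downward step is expected for compound 4: a number 8.9 percentage points lower from compound 3 to compound 4 (within the scatter). Compound 4 is therefore estimated at 16%, within 0% to 38%.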

Compound 4, a percentage reported as inhibition, at one concentration (the size of the read-out at that concentration, not a potency): 12.9%
For compound 4 the middle estimate is 3.1 percentage points above the measured one; the range from low to high includes it.
By their numbers in this assay, from the lowest: compounds 2 and 4 (each within the scatter of the next); then compound 3; then compound 1.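

In this assay, replacing 4-ethylphenyl with naphthalen-1-yl gives a number 12 percentage points lower from compound 3 to compound 4 (beyond the scatter), so a second aryl change at this position also moves the number beyond the scatter. This pair carries a benzyl group where compound 1 and compound 2 carry cyclohexyl, so the position's response is no longer seen with cyclohexyl alone. Nothing available explains the drop. Still open, from the compounds shown here alone, is whether a phenyl group bearing an amine or a carboxylic acid here would raise the number. Also open, going by these compounds, is how naphthalen-1-yl behaves with cyclohexyl in place of benzyl.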